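Adding ethoxymethyl to compound 3: what to expect

The source may report more compounds than this note shows. Statements on the series, on what has been measured and on what is new or still open speak of the compounds shown alone.

Measured so far in an in vitro ADME assay on microsomes from liver (Homo sapiens) for metabolic stability, with a stated time of 15 min; a lower number here means slower removal, a higher number faster removal of the compound:
- Compound 1 `CCc1nn2c(-c3c(C)cc(OC)cc3OC)cccc2c1N(CC1CCOCC1)CC1CC1` gives 450 mL.min-1.g-1
- Compound 2 `CCc1nn2c(-c3c(C)cc(C)cc3OC)cccc2c1N(CC1CCOCC1)CC1CC1` gives 450 mL.min-1.g-1
- Compound 3 `CCc1nn2c(-c3c(OC)cccc3OC)cccc2c1N(CC1CCOCC1)CC1CC1` gives 740 mL.min-1.g-1

Compound 3, at 740 mL.min-1.g-1, lies within the usual scatter of both other compounds, so the three cannot be ranked. Compound 4 `CCOCc1cc(OC)c(-c2cccc3c(N(CC4CCOCC4)CC4CC4)c(CC)nn23)c(OC)c1` differs from compound 3 at a single place, where ethoxymethyl stands in place of hydrogen on an aromatic carbon (ethoxymethyl in place of hydrogen on an aromatic carbon). Among the measured compounds shown here, no measured compound carries ethoxymethyl, so no measured step shows this change directly. The nearest evidence comes from other changes to the same aromatic group: a 1.6-fold higher number from compound 1 to compound 3 (0.22 log units; within the scatter), a 1.6-fold higher number from compound 2 to compound 3 (0.22 log units; within the scatter) and no change at the digits printed from compound 1 to compound 2 (within the scatter). All three stay within the scatter, and none of these compounds goes against that picture. On this limited basis, no step beyond the scatter is expected, and the estimated step is a 1.1-fold lower number from compound 3 to compound 4 (0.02 log units; within the scatter) in this assay, with no firm direction. Going by these compounds, the new group is untested here, so the range is kept wide. Compound 4 is expected at 700 mL.min-1.g-1 with 350 mL.min-1.g-1 to 1400 mL.min-1.g-1 as its estimated range.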

Compound 4, intrinsic clearance in microsomes: 520 mL.min-1.g-1
Estimate against measurement, compound 4: 1.3-fold (0.13 log units) above, within the range that was stated.
By their numbers in this assay, from the lowest: compounds 1, 2, 4 and 3 (each within the scatter of the next).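

In this assay, ethoxymethyl in place of hydrogen on this aromatic carbon, meta to two methoxy groups and para to a large group, gives a 1.4-fold lower number from compound 3 to compound 4 (0.15 log units; within the scatter) and so stays inside the usual scatter. Among the compounds shown here, this is the first sign that this carbon can carry a chain of 4 heavy atoms, with one oxygen and no ring, without a clear shift in the clearance number, whereas the earlier compounds showed only methyl and methoxy variations on this aromatic ring. No measurement shown here explains why the number holds.

Going by these compounds, it remains open whether an amine, a carboxylic acid or a longer chain at this same carbon would produce a step beyond the scatter. Also open, on these data alone, is whether ethoxymethyl would give a similar result if methyl replaced one of the two methoxy groups.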